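Restoring an Alkyl Group on the Ring Nitrogen

The source may hold more compounds than are shown below. What is called first, only, known or untested is meant among the compounds shown, and "the series" means these compounds.

Three compounds have been measured in an assay on V79 cells for inhibition of cytochrome P450 11B2, mitochondrial (Homo sapiens), read by HTRF, with a stated time of 1 h; a higher number here means a weaker inhibitor, a lower number a stronger inhibitor:
Compound 1, `Cn1c(-c2cccnc2)nc2ccc(F)cc21`, gives 12 nM.
Compound 2, `Fc1ccc2nc(-c3cccnc3)n(C3CC3)c2c1`, gives 4 nM.
Compound 3, `Fc1ccc2nc(-c3cccnc3)[nH]c2c1`, gives > 10000 nM, which is a limit of the assay and not a number.

Compound 3 therefore stands at the limit of > 10000 nM in this assay, at which 1 of the 3 values shown sits, the only one of the three to do so, and the shared core differs among them only in what sits on the aromatic nitrogen of the five-membered ring. Going by the values given here, two measured steps bear directly on that position: an at least 830-fold higher number from compound 1 to compound 3 (2.92 log units; beyond the scatter) and an at least 2500-fold higher number from compound 2 to compound 3 (3.39 log units; beyond the scatter), both large, and both involving the removal of a small alkyl group from the aromatic nitrogen. The smaller step of a 3.0-fold lower number from compound 1 to compound 2 (0.48 log units; beyond the scatter) shows that widening the alkyl from methyl to cyclopropyl moved the number a little further down.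

Compound 4, `Fc1ccc2nc(-c3cccnc3)n(C3CCC3)c2c1`, is compound 3 with cyclobutyl in place of hydrogen on an aromatic nitrogen. Because the two large steps of an at least 830-fold higher number from compound 1 to compound 3 (2.92 log units; beyond the scatter) and an at least 2500-fold higher number from compound 2 to compound 3 (3.39 log units; beyond the scatter) were both produced by taking an alkyl group off this nitrogen, putting a cyclobutyl group back on is expected to reverse them, giving a large downward step an at least 2000-fold lower number from compound 3 to compound 4 (3.30 log units; beyond the scatter) in this assay. Compound 4 is thus expected to reach about 5 nM, with a likely range from 1.5 nM to 20 nM.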

Compound 4, half-maximal inhibitory concentration: > 5000 nM
Compound 4: a limit, no number; the forecaster's own chance of this, stated with the estimate: 3%; at least 1000-fold (3.00 log units) between middle value and limit.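

Compound 4 stands at a limit of the assay and not at a number: the limit of > 5000 nM in this assay, at which 1 of the 4 values shown sits. Putting an alkyl group back on this aromatic nitrogen is therefore not enough on its own, and the kind of group matters: in this assay cyclobutyl goes with an at least 1200-fold higher number from compound 2 to compound 4 (3.09 log units; beyond the scatter) and with an at least 410-fold higher number from compound 1 to compound 4 (2.61 log units; beyond the scatter), whereas widening methyl to cyclopropyl had given a 3.0-fold lower number from compound 1 to compound 2 (0.48 log units; beyond the scatter), so the downward trend seen with those two groups does not carry on to cyclobutyl, and compound 4 goes against it. Compound 3 and compound 4 both end in limits, so the step between them cannot be read, and neither compound can be ranked against the other.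

The compounds shown leave open how the low numbers of compound 1 and compound 2 change with open-chain groups on this nitrogen, such as ethyl or isopropyl, which would help show whether the sharp rise belongs to the cyclobutyl ring itself or to any group beyond cyclopropyl. They also leave open whether a longer chain such as propyl or butyl on this nitrogen would give a measurable number in this assay.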